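The source may report more compounds than this note shows. Statements on the series, on what has been measured and on what is new or still open speak of the compounds shown alone.

Measured compounds:
- compound 1, `COc1ccc(-c2cc(/C=C/C(=O)c3ccc(N)cc3)[nH]n2)cc1`: 82%
- compound 2, `COc1cc(-c2cc(/C=C/C(=O)c3ccc(N)cc3)[nH]n2)cc(OC)c1OC`: 91%
- compound 3, `COc1ccc(C(=O)/C=C/c2cc(-c3cc(OC)c(OC)c(OC)c3)n[nH]2)cc1OC`: 87%

In a functional assay on UO-31 cells (Homo sapiens) for cytotoxicity, read by sulforhodamine B assay, with a stated time of 48 h, tested at 0.1 uM (a lower number here means a stronger effect, a higher number a weaker effect of the compound at the concentration tested), compound 2 gives 91%, the highest of the three numbers, with compound 3 at 87% and compound 1 at 82%; both of these lie within the scatter of compound 2, so no ordering can be read from them.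

Compound 4, `COc1ccc(-c2cc(/C=C/C(=O)c3ccc(N)cc3)[nH]n2)cc1OC`, differs from compound 2 by hydrogen in place of methoxy on an aromatic carbon. Among the compounds with values here, no measured step changes this same position. Within the data shown here, the one step that was measured, a number 4 percentage points lower from compound 2 to compound 3 (within the scatter), changes a different part of the molecule and stays within the scatter. Compound 1 and compound 2 also differ in methoxy groups on the same ring, and their values show no difference beyond the scatter.

With nothing shown to move the number, compound 4 is expected to sit close to compound 2, and the step of a number 4 percentage points lower from compound 2 to compound 4 (within the scatter) is estimated to stay within the scatter. Compound 4 is therefore expected to give about 87% in this assay, in the range 76% to 98%.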

Compound 4, a percentage reported as activity, at one concentration (the size of the read-out at that concentration, not a potency): 99%
For compound 4 the middle estimate is 12 percentage points below the measured one; measured number outside the range, above it.
By their numbers in this assay, from the lowest: compounds 1, 3, 2 and 4 (each within the scatter of the next, the first and the last beyond it).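

In this assay the change of methoxy for hydrogen on this ring gives its first step beyond the scatter in the series: a number 17 percentage points higher from compound 1 to compound 4 (beyond the scatter) and this step is modest. The reverse kind of change, hydrogen in place of methoxy on the aromatic carbon ortho to a methoxy group and meta to a large group, gives a number 8 percentage points higher from compound 2 to compound 4 (within the scatter) and so cannot be told apart from repeat variation. A methoxy change on this ring can therefore shift the number, but not in every pair shown, and no measurement here bears on the reason for this.

From the compounds shown here alone, whether a hydroxyl group, a fluorine atom or an amine on this aromatic carbon would shift the number remains open. So does the question of whether these differences persist at other concentrations or in other cell lines.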